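Amine swap on the shared core: compound 3 to compound 4

The compounds below may be only part of what the source reports. "The series", "measured", "known", "first", "only" and "open" are said of these compounds alone.

Compound 1 `CCCc1ccc(NC2=CC(=O)c3c(nc4n3[C@H]3OC[C@@H](O)[C@H]3OC4)C2=O)cc1` in a functional assay on MCF7 cells (Homo sapiens) for inhibition, read by sulforhodamine B assay (on this read-out higher numbers stand for weaker inhibition and lower numbers for stronger inhibition), gives only a limit, > 4000 nM. Compound 2 `Cc1ccc(NC2=CC(=O)c3c(nc4n3[C@H]3OC[C@@H](O)[C@H]3OC4)C2=O)cc1` likewise gives only a limit in this assay, > 4000 nM. Compound 3 `O=C1C(N2CCCC2)=CC(=O)c2c1nc1n2[C@H]2OC[C@@H](O)[C@H]2OC1` in this assay also gives only a limit, > 16000 nM. Compound 3 thus stands at the limit of > 16000 nM in this assay, at which 1 of the 3 values shown sits, while the other two values sit at the limit of > 4000 nM in this assay, at which 2 of the 3 values shown sit; the set holds no numeric value at all. The measured steps, a step that the two limits leave unreadable from compound 1 to compound 2 and a step that the two limits leave unreadable from compound 2 to compound 3, carry no readable size. Compound 4 `O=C1C(NCc2ccccc2)=CC(=O)c2c1nc1n2[C@H]2OC[C@@H](O)[C@H]2OC1` differs from compound 3 by benzylamino in place of pyrrolidin-1-yl on a double-bonded ring carbon. Among the measured compounds shown here, no measured step bears on this change with a readable size, so no shift beyond the scatter is expected. The estimated step is therefore a step that the limit leaves unreadable from compound 3 to compound 4. Compound 4 is expected to give about 20000 nM, within 5000 nM to 80000 nM, most likely again only as a limit.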

Compound 4, half-maximal inhibitory concentration: > 8000 nM
Compound 4 ended at the assay's limit; the forecaster's own chance of this, stated with the estimate: 80%; the middle value is on the limit's open side.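

In this assay compound 4 gives only a limit, > 8000 nM. Among the compounds shown here, compound 1, compound 2 and compound 3 also give only limits, so no step to compound 4 can be read. The compounds shown leave open whether any amine on the shared core gives a numeric value.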